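The source may report more compounds than this note shows. Statements on the series, on what has been measured and on what is new or still open speak of the compounds shown alone.

Compound 1 `CC(C)(C)c1ccc(C(=O)N2CCC3(CC2)C(=O)N(CC(=O)NCCN)CN3c2ccccc2)cc1` and compound 2 `CC(C)(C)OC(=O)NC1CCN(C(=O)CN2CN(c3ccccc3)C3(CCN(C(=O)c4ccc(C5CCCCC5)cc4)CC3)C2=O)CC1` have both been tested in an assay on HEK293 cells for displacement of a labelled ligand from NPC1-like intracellular cholesterol transporter 1 (Homo sapiens); on this read-out lower numbers stand for stronger inhibition and higher numbers for weaker inhibition. In this assay compound 1 gives 7000 nM, and in this assay compound 2 gives 4800 nM. Compound 1 has the higher of the two numbers, yet its gap to compound 2 lies within the usual scatter of such measurements, so the two results cannot be told apart.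

Compound 3 `CC(C)(C)c1ccc(C(=O)N2CCC3(CC2)C(=O)N(CC(=O)N2CCCCC2CO)CN3c2ccccc2)cc1` has not yet been measured. It differs from compound 1 at one place only: 2-(hydroxymethyl)piperidin-1-yl in place of (2-aminoethyl)amino on a carbonyl carbon. Within the data shown here, no pair of measured compounds shows what such a change does, so there is no measured step to lean on. The two values that exist, from compound 1 and from compound 2, sit in the same region, and nothing in them points to a large move in either direction. The change is expected to matter little in this assay: a 1.2-fold lower number from compound 1 to compound 3 (0.07 log units; within the scatter), a step no larger than the scatter. Compound 3 is estimated to give 6000 nM in this assay, with a range from 2000 nM to 20000 nM.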

Compound 3, half-maximal inhibitory concentration: 11800 nM
Beside the measured number, compound 3's estimate is 2.0-fold (0.29 log units) below it; measured number inside the range.
By their numbers in this assay, from the lowest: compounds 2, 1 and 3 (each within the scatter of the next, the first and the last beyond it).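

In this assay, among these compounds, the change on the carbonyl carbon, from (2-aminoethyl)amino to 2-(hydroxymethyl)piperidin-1-yl, gives a 1.7-fold higher number from compound 1 to compound 3 (0.23 log units; within the scatter) and is the first measured step at this place. The entering group has 8 heavy atoms and a six-membered non-aromatic ring with 1 hetero atom, whereas the leaving group has 4 heavy atoms and no ring, and this larger group on the same carbonyl carbon produces no step beyond the scatter. Nothing available explains the size of this step.

The compounds shown leave open whether the ring or the hydroxymethyl group on it matters more at this place, a question that plain piperidin-1-yl on the same carbonyl carbon would address. They also leave open whether any group here can move the number beyond the scatter in either direction, for example a carboxylic acid, a morpholine or a longer chain ending in an amine.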